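Losing the carboxy end of the chain

The source may hold more compounds than are shown below. What is called first, only, known or untested is meant among the compounds shown, and "the series" means these compounds.

Compound 1 `CC(C)=CCn1nc(-c2cccnc2)c2ccccc2c1=O` – 1380 nM
Compound 2 `O=C(O)Cn1nc(-c2cccnc2)c2ccccc2c1=O` – > 100000 nM (a limit of the assay)

In a functional assay (trachea) with Cavia porcellus as the target (on this read-out higher numbers stand for weaker inhibition and lower numbers for stronger inhibition), compound 1 gives 1380 nM as a true number. Compound 2 has only a limit, not a number (the limit of > 100000 nM in this assay, at which 1 of the 2 values shown sits). Compound 3 `NCCn1nc(-c2cccnc2)c2ccccc2c1=O` differs from compound 2 in one place (aminomethyl in place of carboxy on a saturated chain carbon bound to an aromatic nitrogen), with aminomethyl in place of carboxy. The same difference, cut one bond further out, reads carboxymethyl to 2-aminoethyl. For the measured compounds named here, the one measured step bearing on this is an at least 72-fold higher number from compound 1 to compound 2 (1.86 log units; beyond the scatter) and it brought the carboxy in, so compound 3, which drops the carboxy, is expected to move towards stronger inhibition, probably by less than that large step. Going by the values given here, no measured compound carries aminomethyl, so the size remains uncertain. The expected step is an at least 6.6-fold lower number from compound 2 to compound 3 (0.82 log units; beyond the scatter) by this estimate. The estimated value for compound 3 is 15000 nM (expected range 2500 nM to 80000 nM).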

Compound 3, half-maximal inhibitory concentration: > 100000 nM
Compound 3 gave a limit, no number; the forecaster's own chance of this, stated with the estimate: 30%; middle value at least 6.6-fold (0.82 log units) from the limit.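

In this assay compound 3 gives > 100000 nM as a limit of the assay, not a number. Replacing the carboxy with aminomethyl therefore brings back none of the inhibition seen with the 2-methylprop-1-en-1-yl group, and the chain ending in 2-aminoethyl shows an at least 72-fold higher number from compound 1 to compound 3 (1.86 log units; beyond the scatter) for this change. The loss at this saturated chain carbon bound to an aromatic nitrogen is thus not tied to the carboxy alone, and the step between compound 2 and compound 3 cannot be read: the limit of > 100000 nM in this assay, at which 2 of the 3 values shown sit.

Still open, on these data alone, is which part of the 2-methylprop-1-en-1-yl group goes with the stronger inhibition of compound 1. A saturated 3-methylbutyl chain or a benzyl group at this place would show whether the double bond matters or whether a carbon-only end is enough.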